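Lengthening the side chain of compound 3

A few compounds are considered here, and "the series" means these few. Any claim that something is new, unique, unknown or untested is made for them only; others in the source may bear on it.

In a functional assay on HCC827 cells (Homo sapiens) for inhibition, read by fluorescence, with a stated time of 72 h (on this read-out lower numbers stand for stronger inhibition of growth and higher numbers for weaker inhibition of growth), compound 1 (`CC(C)CCn1cnc2c(Nc3ccc(Cl)cc3)nc(N[C@H]3CC[C@H](N)CC3)nc21`) gives 10200 nM while compound 2 (`CCCCCCn1cnc2c(Nc3ccc(Cl)cc3)nc(N[C@H]3CC[C@H](N)CC3)nc21`) gives 11700 nM and compound 3 (`COc1cc(Nc2nc(N[C@H]3CC[C@H](N)CC3)nc3c2ncn3CCC(C)C)cc(OC)c1`) gives 11200 nM in the same test. Compound 3 thus stands level with the other two, inside the scatter. Compound 4 (`CCCCCCn1cnc2c(Nc3cc(OC)cc(OC)c3)nc(N[C@H]3CC[C@H](N)CC3)nc21`) differs from compound 3 by one change (butyl in place of isopropyl on a saturated chain carbon, two bonds along the chain from an aromatic nitrogen) on the side chain. The same replacement gave a 1.1-fold higher number from compound 1 to compound 2 (0.06 log units; within the scatter) when measured alone. The swap of 3,5-dimethoxyphenyl for 4-chlorophenyl gave a 1.1-fold higher number from compound 1 to compound 3 (0.04 log units; within the scatter) and thus also moved nothing measurably. An a 1.1-fold higher number from compound 3 to compound 4 (0.03 log units; within the scatter) is therefore expected in this assay with no shift beyond the scatter. The estimate for compound 4 is 12000 nM with an expected range from 6500 nM to 22000 nM in this test.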

Compound 4, concentration for 50% growth inhibition: 9100 nM
Estimate against measurement, compound 4: 1.3-fold (0.12 log units) above; low and high end bracket the measured number.
By their numbers in this assay, from the lowest: compounds 4, 1, 3 and 2 (each within the scatter of the next).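

In this assay, butyl in place of isopropyl on a saturated chain carbon, two bonds along the chain from an aromatic nitrogen, now also gives no measurable shift on the 3,5-dimethoxyphenyl series, with a 1.2-fold lower number from compound 3 to compound 4 (0.09 log units; within the scatter), so the null result holds on two cores: the same change on two cores in this assay, a 1.1-fold higher number (0.06 log units; within the scatter) from compound 1 to compound 2 and a 1.2-fold lower number (0.09 log units; within the scatter) from compound 3 to compound 4, 1.4-fold (0.15 log units) apart, within the scatter of two such steps. The swap of 3,5-dimethoxyphenyl for 4-chlorophenyl, read on the longer chain, gives a 1.3-fold lower number from compound 2 to compound 4 (0.11 log units; within the scatter) and also holds on two cores: the same change on two cores in this assay, a 1.1-fold higher number (0.04 log units; within the scatter) from compound 1 to compound 3 and a 1.3-fold lower number (0.11 log units; within the scatter) from compound 2 to compound 4, 1.4-fold (0.15 log units) apart, within the scatter of two such steps.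

Going by these compounds, whether a chain longer than the hexyl of compound 4, or an amine on that chain, would shift the number stays open. So does the effect of a carboxylic acid on the phenyl ring.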